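The source may hold more compounds than are shown below. What is called first, only, known or untested is meant among the compounds shown, and "the series" means these compounds.

Compound 1 `CC(CNCC1CC1)Oc1cccc2ccc(N)nc12`: 80 nM
Compound 2 `CC(CNC1CCCC1)Oc1cccc2ccc(N)nc12`: 30 nM

Among the compounds with values here, in an assay on cells with melanin-concentrating hormone receptor 1 (Homo sapiens) as the target, read by radioligand binding (a higher number here means a weaker inhibitor, a lower number a stronger inhibitor), compound 1 gives 80 nM, the higher of the two numbers measured so far. Compound 2, which differs only at the amine nitrogen, gives 30 nM in this assay, and the step of a 2.7-fold lower number from compound 1 to compound 2 (0.43 log units; beyond the scatter) is beyond the scatter. Compound 3 `COc1cccc(CNCC(C)Oc2cccc3ccc(N)nc23)c1` is not yet measured. It differs from compound 1 by 3-methoxyphenyl in place of cyclopropyl on a saturated chain carbon bound to an amine nitrogen. Within the data shown here, the only measured step, a 2.7-fold lower number from compound 1 to compound 2 (0.43 log units; beyond the scatter), also alters the substituent at the amine nitrogen, but the change in compound 3 is of a different kind, so it bears on the prediction only loosely. The expectation for compound 3 in this assay is therefore a modest step, a 1.6-fold lower number from compound 1 to compound 3 (0.20 log units; within the scatter), in either direction possible. Compound 3 is estimated at 50 nM, with a range from 12 nM to 200 nM.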

Compound 3, half-maximal inhibitory concentration: 1 nM
The estimate for compound 3 lay 50-fold (1.70 log units) above the measured number; measured number below the stated range.
By their numbers in this assay, from the lowest: compound 3; then compound 2; then compound 1.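

In this assay the saturated chain carbon bound to an amine nitrogen proves far more responsive than the earlier pair suggested: 3-methoxyphenyl in place of cyclopropyl gives an 80-fold lower number from compound 1 to compound 3 (1.90 log units; beyond the scatter) and is the larger change in number, while the cyclopentyl change gave only a 2.7-fold lower number from compound 1 to compound 2 (0.43 log units; beyond the scatter) in the same assay. The six-membered aromatic ring of carbon only, with its single hydrogen-bond acceptor, is therefore not merely tolerated at this place but goes with the lowest number of the three compounds. The data offer no measured explanation for the size of this step.

The compounds shown leave open whether the aromatic ring or the methoxy group accounts for the step. A plain phenyl, a cyclohexyl or a 4-methoxyphenyl group at this place would be needed to separate the two.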